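The compounds below may be only part of what the source reports. "The series", "measured", "known", "first", "only" and "open" are said of these compounds alone.

Measured in a functional assay on WIL2-NS cells (Homo sapiens); a higher number here means a weaker inhibitor, a lower number a stronger inhibitor:
- compound 1 `NC(=O)c1nn([C@@H]2O[C@H](CO)[C@@H](O)[C@H]2O)cc1I`: > 300000 nM, a limit of the assay and not a number
- compound 2 `COC(=O)c1nn([C@@H]2O[C@H](CO)[C@@H](O)[C@H]2O)cc1I`: 1600 nM

Compound 1 stands at the limit of > 300000 nM in this assay, at which 1 of the 2 values shown sits. Compound 3 `C#Cc1cn([C@@H]2O[C@H](CO)[C@@H](O)[C@H]2O)nc1C(N)=O` keeps the carbamoyl group of compound 1 and differs in one place: ethynyl in place of iodo on an aromatic carbon. This is ethynyl in place of iodo on an aromatic carbon, next to the ring atom that bears a carbamoyl group.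

For the measured compounds named here, the only measured step is an at least 180-fold lower number from compound 1 to compound 2 (2.27 log units; beyond the scatter). It is large and beyond the scatter, but it is methoxy in place of amino on a carbonyl carbon, not a change at the place that differs in compound 3. It bears on the question only indirectly, showing that a single change to compound 1 can give a measurable value, as compound 2 does with 1600 nM. Going by the values given here, no measured step covers ethynyl in place of iodo, so the expectation is loose: a moderate to large move towards a lower number in this assay, with a real chance of no measurable change.

The estimated step is an at least 10-fold lower number from compound 1 to compound 3 (1.00 log units; beyond the scatter). Compound 3 is estimated at 30000 nM, with an expected range of 2000 nM to 300000 nM.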

Compound 3, half-maximal inhibitory concentration: > 300000 nM
Compound 3: no number, only a limit (the forecaster's own chance of this, stated with the estimate: 30%); middle value at least 10-fold (1.00 log units) away from the limit.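

In this assay compound 3 gives > 300000 nM as a limit of the assay and not a number. For the compounds shown here, compound 1 also stands at a limit there, so no step between compound 1 and compound 3 can be read: the limit of > 300000 nM in this assay, at which 2 of the 3 values shown sit. The compounds shown leave open what ethynyl in place of iodo does to the value on the shared core.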